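A few compounds are considered here, and "the series" means these few. Any claim that something is new, unique, unknown or untested is made for them only; others in the source may bear on it.

In an assay for displacement of a labelled ligand from Adrenergic receptor alpha-1 (Homo sapiens) (on this read-out lower numbers stand for stronger inhibition and higher numbers for weaker inhibition), compound 1 `Cn1c(=O)cnn(CCCCN2CCN(c3ccccc3)CC2)c1=O` gives 64 nM. Compound 2 `Cn1c(=O)cnn(CCCCN2CCN(c3cccc(O)c3)CC2)c1=O` reaches only the limit of this assay, > 10000 nM, and so no number is known for it (the limit of > 10000 nM in this assay, at which 1 of the 3 values shown sits). Compound 3 `Cn1c(=O)cnn(CCCCN2CCN(c3ccccc3F)CC2)c1=O` gives 9.73 nM, the lowest of the two numbers shown; the nearest other number lies at a 6.6-fold lower number from compound 1 to compound 3 (0.82 log units; beyond the scatter). Compound 4 `Cn1c(=O)cnn(CCCCN2CCN(c3ncccc3F)CC2)c1=O` differs from compound 3 in one place: 3-fluoropyridin-2-yl in place of 2-fluorophenyl on an amine nitrogen in a ring. Within the data shown here, two measured steps bear on changes to this aromatic ring: a 6.6-fold lower number from compound 1 to compound 3 (0.82 log units; beyond the scatter), and an at least 150-fold higher number from compound 1 to compound 2 (2.19 log units; beyond the scatter). Neither of them exchanges a ring carbon for a ring nitrogen, so the step is expected to be a 2.6-fold higher number from compound 3 to compound 4 (0.41 log units; beyond the scatter), toward a somewhat higher number. Compound 4 is therefore estimated at 25 nM, within a range from 8 nM to 80 nM.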

Compound 4, inhibition constant: > 10000 nM
Compound 4: no number, only a limit (the forecaster's own chance of this, stated with the estimate: 3%); middle value at least 400-fold (2.60 log units) away from the limit.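

In this assay compound 4 gives no number, only a limit: the limit of > 10000 nM in this assay, at which 2 of the 4 values shown sit. With the fluoro kept, exchanging one ring carbon of this aromatic ring for a ring nitrogen brings an at least 1000-fold higher number from compound 3 to compound 4 (3.01 log units; beyond the scatter), and the same 3-fluoropyridin-2-yl in place of phenyl brings an at least 150-fold higher number from compound 1 to compound 4 (2.19 log units; beyond the scatter), so the fluoro gain seen earlier does not survive this exchange. The step between compound 2 and compound 4 cannot be read, since both are limits.

From the compounds shown here alone, it remains open whether an unsubstituted pyridin-2-yl would also reach the limit. Whether a pyrimidin-2-yl or a 2-methoxyphenyl on the same amine nitrogen would give a number is open too.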